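A few compounds are considered here, and "the series" means these few. Any claim that something is new, unique, unknown or untested is made for them only; others in the source may bear on it.

Compound 1 `Brc1ccc(-c2cn3ccnc3c(-c3ccc4ncn(C5CCCCC5)c4c3)n2)cc1`: 16.2%
Compound 2 `Fc1ccccc1-c1cn2ccnc2c(-c2ccc3ncn(C4CCCCC4)c3c2)n1`: 16%

For the measured compounds named here, in a functional assay on EKVX cells (Homo sapiens) for inhibition, read by sulforhodamine B assay, with a stated time of 48 h, tested at 10 uM (on this read-out lower numbers stand for less inhibition and higher numbers for more inhibition at the one concentration tested (going by the name of the read-out)), compound 2 gives 16%, while compound 1 gives 16.2%; the two numbers lie within the scatter of each other, the only measured step being a number 0.2 percentage points lower from compound 1 to compound 2 (within the scatter). Compound 3 `FC(F)(F)c1cccc(-c2cn3ccnc3c(-c3ccc4ncn(C5CCCCC5)c4c3)n2)c1` differs from compound 2 by 3-(trifluoromethyl)phenyl in place of 2-fluorophenyl on an aromatic carbon. Going by the values given here, that one measured step, which also swapped one substituted phenyl for another, stayed within the scatter, and no step tests a trifluoromethyl group, so no shift beyond the scatter is expected in this assay. Compound 3 is estimated at 16%, between 4% and 30%. This amounts to an expected step of no change at the digits printed from compound 2 to compound 3 (within the scatter).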

Compound 3, a percentage reported as inhibition, at one concentration (the size of the read-out at that concentration, not a potency): 4.79%
Compound 3: the middle estimate sits 11.2 percentage points above what was measured; the range from low to high includes it.
By their numbers in this assay, from the lowest: compound 3; then compounds 2 and 1 (each within the scatter of the next).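

In this assay the group on this aromatic carbon can move the read-out: 3-(trifluoromethyl)phenyl gives a number 11.2 percentage points lower from compound 2 to compound 3 (beyond the scatter) and a number 11.4 percentage points lower from compound 1 to compound 3 (beyond the scatter), whereas the swap between the two halogen-bearing phenyl groups had stayed within the scatter. Substituted phenyl groups at this place are therefore not all interchangeable. Nothing available bears on why the number falls. Going by these compounds, it remains open whether the trifluoromethyl group itself or its place on the phenyl ring carries the step, and how a methoxy group, an amine or a carboxylic acid on that ring would read.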